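Thiophene carboxamide series: thiourea aryl substituent exchange

This account rests on a few compounds, and the source may have more. Where it says the series, first, only, none or still open, it means among the compounds named here.

Measured so far:
compound 1, `NC(=O)c1c(NC(=O)c2ccccc2Cl)sc2c1CCN(Cc1c(Cl)cccc1Cl)C2`: 28800 nM
compound 2, `NC(=O)c1c(NC(=O)c2ccccc2Cl)sc2c1CCN(C(=S)Nc1ccccc1C(F)(F)F)C2`: 26700 nM

In a functional assay on HeLa cells (Homo sapiens) for antiproliferative activity, with a stated time of 24 h (on this read-out higher numbers stand for weaker inhibition and lower numbers for stronger inhibition), compound 2 gives 26700 nM. Compound 1 gives 28800 nM in this assay, and the two numbers lie within the scatter of each other, so neither compound can be set apart from the other. Both numbers sit at the weak end of what this assay resolves.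

Compound 3, `COc1ccccc1NC(=S)N1CCc2c(sc(NC(=O)c3ccccc3Cl)c2C(N)=O)C1`, has yet to be run. It differs from compound 2 in one place: methoxy in place of trifluoromethyl on an aromatic carbon. Among the compounds with values here, no pair of measured compounds shares this kind of change, so there is nothing in hand on which to ground a direction. The expectation is for no step beyond the scatter, with the estimated step of a 1.0-fold higher number from compound 2 to compound 3 (0.00 log units; within the scatter). On that basis compound 3 is expected to give 27000 nM in this assay, within a range from 9000 nM to 80000 nM.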

Compound 3, half-maximal inhibitory concentration: > 50000 nM
Compound 3: a limit, no number; the forecaster's own chance of this, stated with the estimate: 20%; middle value at least 1.8-fold (0.26 log units) away from the limit.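

In this assay compound 3 is a limit and not a number: the limit of > 50000 nM in this assay, at which 1 of the 3 values shown sits. Within the data shown here, this is the first read on a substituent exchange at this aromatic carbon, and methoxy in place of trifluoromethyl gives an at least 1.8-fold higher number from compound 2 to compound 3 (0.27 log units; that floor lies within the scatter), so the change brings no gain in inhibition, while a real loss is not established and its full size cannot be read. Against the other measured compound the reading is an at least 1.7-fold higher number from compound 1 to compound 3 (0.23 log units; that floor lies within the scatter), which likewise leaves no established difference between the groups on the amine nitrogen in the ring.

On these data alone, what stays open is whether any substituent at this aromatic carbon gives a number clearly lower than those of compound 1 and compound 2. Chlorine, hydroxyl or an amine there, or a phenyl with no substituent, would bear on that question.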